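The source may report more compounds than this note shows. Statements on the series, on what has been measured and on what is new or still open speak of the compounds shown alone.

Working notes on a series of three measured imides sharing one core. Compound 1 `CN1C(=O)C(c2ccccc2)CC(c2ccccc2)C1=O` bears methyl on the amide-type nitrogen in the ring; in a functional assay on the whole organism (strain Swiss albino) for inhibition, with Mus musculus as the target, in the maximal electroshock model, with a stated time of 2 h, at a dose of 25 mg/kg by the intraperitoneal route (a lower number here means less inhibition, a higher number more inhibition at the dose given (going by the name of the read-out)), compound 1 gives 69.1%. Compound 2 `O=C1C(c2ccccc2)CC(c2ccccc2)C(=O)N1c1ccccc1` gives 38.3%, and compound 3 `O=C1C(c2ccccc2)CC(c2ccccc2)C(=O)N1Cc1ccccc1` gives 64.5%. On these numbers compound 3 stands second of the three: its gap to compound 1 is within the scatter, its gap to compound 2 is beyond it. All three recorded steps alter the group on that same nitrogen: a number 30.8 percentage points lower from compound 1 to compound 2 (beyond the scatter), a number 26.2 percentage points higher from compound 2 to compound 3 (beyond the scatter), and a number 4.6 percentage points lower from compound 1 to compound 3 (within the scatter).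

The next compound, compound 4 `NN1C(=O)C(c2ccccc2)CC(c2ccccc2)C1=O`, changes the same position once more: amino in place of benzyl on an amide-type nitrogen in a ring. Every step seen so far bears on it, since each one exchanges the group on this nitrogen. Going by the values given here, the only step beyond the scatter, a number 30.8 percentage points lower from compound 1 to compound 2 (beyond the scatter), went with phenyl directly on the nitrogen, and its reversal, a number 26.2 percentage points higher from compound 2 to compound 3 (beyond the scatter), recovered most of it; methyl and benzyl at this nitrogen, a number 4.6 percentage points lower from compound 1 to compound 3 (within the scatter), stayed within the scatter. Among the compounds with values here, with amino no precedent exists, so the expectation is no step beyond the scatter, with room for a downward drift. The estimate for compound 4 is 58%, within 38% to 78%. This corresponds to an expected step of a number 6.5 percentage points lower from compound 3 to compound 4 (within the scatter).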

Compound 4, a percentage reported as inhibition, in the whole organism at one dose (the size of the read-out at that dose, not a potency): 76%
Estimate against measurement, compound 4: 18 percentage points below, within the range that was stated.
By their numbers in this assay, from the lowest: compound 2; then compounds 3, 1 and 4 (each within the scatter of the next, the first and the last beyond it).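

Amino on this nitrogen is the first group shown to stand above benzyl beyond the scatter in this assay, with a number 11.5 percentage points higher from compound 3 to compound 4 (beyond the scatter), so exchanging a group of seven carbon atoms and an aromatic ring for a single nitrogen carries no penalty in this read-out. Methyl now sits within the scatter of both benzyl and amino, with a number 6.9 percentage points higher from compound 1 to compound 4 (within the scatter), although those two groups lie beyond the scatter of each other, while phenyl directly on the nitrogen remains well apart, with a number 37.7 percentage points higher from compound 2 to compound 4 (beyond the scatter). No measurement is available that explains why amino gives this result.

The compounds shown leave open whether the step depends on the nitrogen atom of amino or on its hydrogens, a question that dimethylamino, acetylamino or hydroxyl on the same nitrogen would address. Also open, going by these compounds, is whether a longer chain such as ethyl or propyl would stay within the scatter of methyl and benzyl, and whether these percentages at one dose and one time would hold at other doses.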